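The compounds below may be only part of what the source reports. "The series", "measured", "known", "first", "only" and "open" are said of these compounds alone.

Series notes, heteroaryl variation on the aryl ring.

Of the compounds shown here, three have been measured in a functional assay on HEK293 cells for agonist activity at Bombesin receptor subtype-3 (Homo sapiens), read by luminescence and calcium flux, with a stated time of 10 min; a lower number here means that less compound is needed, a higher number that more compound is needed for the effect. Compound 1 `c1ccc(-c2ccc(CCc3nc(CC4CCCC4)c[nH]3)cc2)nc1` gives 98 nM. Compound 2 `CCC(C)(C)Cc1c[nH]c(CCc2ccc(-c3csnn3)cc2)n1` gives 104 nM. Compound 3 `CCC(C)(C)Cc1c[nH]c(CCc2ccc(-n3ncnn3)cc2)n1` gives 89 nM, the lowest of the three numbers, though its gaps to compound 1 and to compound 2 both sit within the scatter, so no order among the three is claimed.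

Among the compounds with values here, the one step recorded so far, a 1.2-fold lower number from compound 2 to compound 3 (0.07 log units; within the scatter), exchanged one five-membered heteroaryl for another at the same aromatic carbon and left the number essentially where it was.

Compound 4 `CCC(C)(C)Cc1c[nH]c(CCc2ccc(-n3ccnn3)cc2)n1` is not yet measured in this assay. It differs from compound 3 in one place: 1H-1,2,3-triazol-1-yl in place of 2H-tetrazol-2-yl on an aromatic carbon. Within the data shown here, the change is of the same kind as the one in the step from compound 2 to compound 3, a small five-membered heteroaryl swapped for another of like size at the same position, and that step stayed within the scatter. Among the measured compounds shown here, no other step bears on it.

On this basis compound 4 is expected to remain close to compound 3, with an estimated 1.2-fold higher number from compound 3 to compound 4 (0.09 log units; within the scatter) that does not clearly exceed the scatter. The estimate for compound 4 in this assay is 110 nM, with a range from 45 nM to 270 nM.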

Compound 4, half-maximal effective concentration: 93 nM
For compound 4 the middle estimate is 1.2-fold (0.07 log units) above the measured one; measured number inside the range.
By their numbers in this assay, from the lowest: compounds 3, 4, 1 and 2 (each within the scatter of the next).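

In this assay, 1H-1,2,3-triazol-1-yl in place of 2H-tetrazol-2-yl, on an aromatic carbon para to a large group, gives a 1.0-fold higher number from compound 3 to compound 4 (0.02 log units; within the scatter), so a five-membered aromatic ring with 3 hetero atoms and 3 hydrogen-bond acceptors reads the same within the scatter as one with 4 of each. With 1H-1,2,3-triazol-1-yl in place of 1,2,3-thiadiazol-4-yl the step is a 1.1-fold lower number from compound 2 to compound 4 (0.05 log units; within the scatter), which, taken with a 1.2-fold lower number from compound 2 to compound 3 (0.07 log units; within the scatter), leaves compound 2, compound 3 and compound 4 all within the scatter of one another, a flat reading that holds for these three five-membered rings at this position and for no group beyond them. No measurement bearing on the groups themselves is available to account for this flat reading.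

From the compounds shown here alone, it remains open whether the number holds at this position with a group of another kind, such as a carboxylic acid, a primary amine or a longer alkyl chain. Compound 1 differs from compound 2, compound 3 and compound 4 in more than one place, so it gives no separate reading of this position.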